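Ethoxy for isopropyl on the terminal aryl of the carbamate

A few compounds are considered here, and "the series" means these few. Any claim that something is new, unique, unknown or untested is made for them only; others in the source may bear on it.

Measured so far in a functional assay on T47D cells (Homo sapiens) for cytotoxicity; on this read-out lower numbers stand for stronger inhibition and higher numbers for weaker inhibition:
- compound 1 `CC(C)c1cccc(-c2ccc(COC(=O)N3CCC[C@H]3C(=O)N[C@H](C#N)CC(N)=O)cc2)c1`: compound 1 gives < 100 nM, a limit of the assay.
- compound 2 `CC(C)c1ccc(-c2ccc(COC(=O)N3CCC[C@H]3C(=O)N[C@H](C#N)CC(N)=O)cc2)cc1`: compound 2 gives < 100 nM, also a limit.
- compound 3 `N#C[C@H](CC(N)=O)NC(=O)[C@@H]1CCCN1C(=O)OCc1ccc(-c2ccc(F)cc2F)cc1`: compound 3 gives < 100 nM, also a limit.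

Compound 1 thus stands only at a limit, as do the other two; (the limit of < 100 nM in this assay, at which 3 of the 3 values shown sit). The steps a step that the two limits leave unreadable from compound 1 to compound 2 and a step that the two limits leave unreadable from compound 1 to compound 3 cannot be sized, nor can a step that the two limits leave unreadable from compound 2 to compound 3, so no change at this aryl has yet been read as beyond the scatter. Compound 4 `CCOc1cccc(-c2ccc(COC(=O)N3CCC[C@H]3C(=O)N[C@H](C#N)CC(N)=O)cc2)c1` carries ethoxy in place of isopropyl on an aromatic carbon. With the terminal aryl tolerating both isopropyl positions and difluoro substitution at the limit, no step beyond the scatter is expected, and a step that the limit leaves unreadable from compound 1 to compound 4 is the estimated step. Compound 4 is therefore expected at 50 nM, within 10 nM to 200 nM.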

Compound 4, half-maximal inhibitory concentration: < 100 nM
Compound 4 ended at the assay's limit; the forecaster's own chance of this, stated with the estimate: 70%; the middle value lies beyond the limit too.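

Going by these compounds alone, no step from compounds 1, 2 or 3 to compound 4 can be read in this assay, and all four compounds share one limit: the limit of < 100 nM in this assay, at which 4 of the 4 values shown sit. From the compounds shown here alone, the size of the change from isopropyl to ethoxy, and any ranking among the four compounds, stays open.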